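From bromo to 2-carboxyethenyl on compound 3

The source may report more compounds than this note shows. Statements on the series, on what has been measured and on what is new or still open speak of the compounds shown alone.

Compound 1 `Cc1cc(Br)cc(C)c1Oc1ccc([N+](=O)[O-])c(Nc2ccc(C#N)cc2)n1`: 65100 nM
Compound 2 `CC(=O)/C=C/c1cc(C)c(Oc2cc(Nc3ccc(C#N)cc3)c([N+](=O)[O-])cc2[N+](=O)[O-])c(C)c1`: > 100000 nM
Compound 3 `Cc1cc(Br)cc(C)c1Oc1ccc(N)c(Nc2ccc(C#N)cc2)n1`: 9610 nM

In an ADME assay on MT2 cells (Homo sapiens) for cytotoxicity, read by XTT assay, with a stated time of 4 days (on this read-out higher numbers stand for lower toxicity in this test and lower numbers for higher toxicity in this test), compound 3 gives 9610 nM, the lower of the two actual numbers. Compound 4 `Cc1cc(/C=C/C(=O)O)cc(C)c1Oc1ccc(N)c(Nc2ccc(C#N)cc2)n1` carries 2-carboxyethenyl in place of bromo on an aromatic carbon. Going by the values given here, the one measured step, a 6.8-fold lower number from compound 1 to compound 3 (0.83 log units; beyond the scatter), comes with amino in place of nitro on an aromatic carbon, so it does not touch this change. Compound 2 also lacks the bromo and gives > 100000 nM, which is a limit, so a move to a higher number is expected, though only loosely. The expected step is a 3.6-fold higher number from compound 3 to compound 4 (0.56 log units; beyond the scatter). For compound 4 the estimate is 35000 nM, with an expected range from 10000 nM to 100000 nM.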

Compound 4, half-maximal cytotoxic concentration: 15700 nM
Estimate against measurement, compound 4: 2.2-fold (0.35 log units) above; measured number inside the range.
By their numbers in this assay, from the lowest: compounds 3 and 4 (each within the scatter of the next); then compound 1. At a limit, above all of these: compound 2.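

In this assay, 2-carboxyethenyl in place of bromo, on the aromatic carbon meta to two methyl groups, gives a 1.6-fold higher number from compound 3 to compound 4 (0.21 log units; within the scatter), so this larger group, with its hydrogen-bond donor and acceptor, brings no change beyond the scatter at this position. Going by these compounds alone, the only earlier step was amino in place of nitro, at another place, so this is the first reading of this position. Compound 2, which also lacks the bromo, gives only a limit and no step: the limit of > 100000 nM in this assay, at which 1 of the 4 values shown sits.

From the compounds shown here alone, it remains open whether the carboxylic acid or the double bond of the chain counts here. A methyl ester, a saturated propanoic acid chain or an amine at this position might read differently.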